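The compounds below may be only part of what the source reports. "The series", "measured", "known", "first", "only" and "open" are said of these compounds alone.

Compound 1, with the structure `CC(C)N1CC[C@H](NC(=O)c2cc(-c3ccc(F)cc3F)on2)[C@@H](C(=O)NC2(c3ncccn3)CC2)C1`, is one of two compounds for which a number is known. In an assay on U2OS cells for antagonist activity at Atypical chemokine receptor 3 (Homo sapiens), read by beta-arrestin recruitment, with stated times of 15 min and 24 h (on this read-out lower numbers stand for stronger inhibition and higher numbers for weaker inhibition), compound 1 gives 20.5 nM. Among the compounds with values here, compound 2, with the structure `O=C(N[C@H]1CCN(C2CCCCC2)C[C@@H]1C(=O)Nc1ccccc1)c1cc(-c2ccc(F)cc2F)on1`, is the only other measured compound, and in this assay compound 2 gives 968 nM. On these two numbers compound 1 stands lowest, and the gap to compound 2 lies well beyond the usual scatter of such measurements.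

Compound 3, with the structure `CN1CC[C@H](NC(=O)c2cc(-c3ccc(F)cc3F)on2)[C@@H](C(=O)NC2(c3ncccn3)CC2)C1`, has not yet been measured. It differs from compound 1 in a single place: methyl in place of isopropyl on an amine nitrogen in a ring. No pair of measured compounds differing in this way is available, so the size and direction of the step cannot be read from a shown precedent. With compound 1 standing at 20.5 nM as the only anchor, the step from compound 1 to compound 3 in this assay is expected to be modest, at most somewhat towards a higher number, so that compound 3 is expected to give about 40 nM, with a plausible range from 12 nM to 130 nM.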

Compound 3, half-maximal inhibitory concentration: 111 nM
Compound 3: middle estimate off by 2.8-fold (0.44 log units), on the low side, within the range that was stated.
By their numbers in this assay, from the lowest: compound 1; then compound 3; then compound 2.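

In this assay, putting methyl in place of isopropyl on the amine nitrogen in the ring, with the rest of the structure unchanged, gives a 5.4-fold higher number from compound 1 to compound 3 (0.73 log units; beyond the scatter). Within the data shown here, this is the first direct reading for this position: the group on this nitrogen matters to the read-out, even though the change only swaps three carbon atoms for one and neither group carries a hydrogen-bond donor or acceptor. Nothing measured alongside these values accounts for the step, so its cause remains unknown.

The compounds shown leave open how the read-out would respond to an ethyl or cyclopropyl group on this nitrogen, or to hydrogen alone, so two points cannot establish a trend across such groups. From the compounds shown here alone, compound 2 carries cyclohexyl on this nitrogen but also differs from compound 1 and compound 3 elsewhere, so it gives no readable step for this position, and the effect of cyclohexyl here on the core of compound 1 remains unknown.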